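Trifluoromethyl for fluoro on a quinoline-indole microsomal series

The source may report more compounds than this note shows. Statements on the series, on what has been measured and on what is new or still open speak of the compounds shown alone.

Measured so far:
compound 1, `Cc1cccc2c(-c3ccc4c(O)cccc4n3)c[nH]c12`, 0.283 h in an ADME assay on microsomes from liver (Homo sapiens) for metabolic stability, using NADPH, with a stated time of 40 min, tested at 2 uM; on this read-out lower numbers stand for a shorter-lived compound and higher numbers for a longer-lived compound
compound 2, `Cc1cccc2c(-c3ccc4c(F)cccc4n3)c[nH]c12`, 0.217 h
compound 3, `Fc1ccc2c(-c3ccc4ccccc4n3)c[nH]c2c1Cl`, 0.183 h

On these numbers compound 2 stands second highest of three, but compound 3 and compound 1 both sit within the scatter of it, so no order among the three can be claimed. Compound 4, `Cc1cccc2c(-c3ccc4c(C(F)(F)F)cccc4n3)c[nH]c12`, differs from compound 2 by trifluoromethyl in place of fluoro on an aromatic carbon. Going by the values given here, the one step measured at that place, a 1.3-fold lower number from compound 1 to compound 2 (0.12 log units; within the scatter), stayed within the scatter; no step from fluoro to trifluoromethyl is on record. From this the account expects no change beyond the scatter in this assay, that is a 1.1-fold higher number from compound 2 to compound 4 (0.03 log units; within the scatter), and estimates compound 4 at 0.23 h with a range from 0.12 h to 0.45 h.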

Compound 4, half-life: 1.25 h
Compound 4: middle estimate off by 5.4-fold (0.74 log units), on the low side; measured number above the stated range.
By their numbers in this assay, from the lowest: compounds 3, 2 and 1 (each within the scatter of the next); then compound 4.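

In this assay this place proves able to shift the half-life: trifluoromethyl in place of fluoro gives a 5.8-fold higher number from compound 2 to compound 4 (0.76 log units; beyond the scatter) and trifluoromethyl in place of hydroxy gives a 4.4-fold higher number from compound 1 to compound 4 (0.65 log units; beyond the scatter) at the same aromatic carbon. Exchanging hydroxy for fluoro there had stayed within the scatter, so the change that counts here is the entry of trifluoromethyl. No measurement at hand explains this rise.

The compounds shown do not tell whether a methyl, a methoxy or a nitrile at this place would read like trifluoromethyl, or whether trifluoromethyl would do the same on the core of compound 3.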